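This account rests on a few compounds, and the source may have more. Where it says the series, first, only, none or still open, it means among the compounds named here.

The shared core of these compounds carries a sulfur-nitrogen ring fused to a benzene ring. Compound 1, `N=S1(=O)c2ccccc2C(=O)N1c1ccccc1`, has a phenyl group on the ring nitrogen, and in an ADME assay on microsomes from liver (Homo sapiens) for metabolic stability (a lower number here means slower removal, a higher number faster removal of the compound), compound 1 gives 93.5 mL.min-1.g-1. Compound 2, `NC1=NS(=O)(=O)c2ccccc21`, carries an amino group on the ring carbon instead. In this assay compound 2 returns only < 3 mL.min-1.g-1, which is a limit of the measurement and not a number. Compound 3, `CCN=S1(=O)NC(=O)c2ccccc21`, has an ethyl group on the exocyclic nitrogen of the sulfur atom. In this assay compound 3 also returns only < 3 mL.min-1.g-1, again a limit rather than a number. Compound 2 thus sits at the limit of < 3 mL.min-1.g-1 in this assay, at which 2 of the 3 values shown sit. Among the measured compounds shown here, no pair of these three differs in only one place, so no single step can be read from them.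

The compound not yet measured is compound 4, `CCNC1=NS(=O)(=O)c2ccccc21`. It differs from compound 2 by ethyl in place of hydrogen on an amine nitrogen. For the measured compounds named here, with no measured step to lean on, the change from compound 2 to compound 4 is expected to move the reading upward by a modest amount, as an at least 2.6-fold higher number from compound 2 to compound 4 (0.42 log units; beyond the scatter). The reading for compound 4 in this assay is expected to be about 8 mL.min-1.g-1, within a range from 3 mL.min-1.g-1 to 30 mL.min-1.g-1.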

Compound 4, intrinsic clearance in microsomes in the liver assay: < 3 mL.min-1.g-1
Compound 4: a limit, no number (the forecaster's own chance of this, stated with the estimate: 35%); middle value at least 2.6-fold (0.42 log units) away from the limit.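

Compound 2 and compound 4 both sit at a limit of the liver assay rather than at a number, so no step can be read between them: the limit of < 3 mL.min-1.g-1 in the liver assay, at which 3 of the 4 values shown sit.

In a physicochemical assay for acid dissociation, read by spectrophotometry, compound 2 gives 11.4 and compound 4 gives 11.7. In the physicochemical assay this is a number 0.30 log units higher from compound 2 to compound 4 (within the scatter). On these data alone, whether ethyl in place of hydrogen on an amine nitrogen changes the rate of removal at all stays open.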